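Chloro in Place of Methyl on the Anilino Ring

The compounds below may be only part of what the source reports. "The series", "measured", "known", "first", "only" and "open" are said of these compounds alone.

Three measured compounds frame this comparison: compound 1 `Cc1nc(Nc2ccc(Cl)c(Cl)c2)sc1C(=O)/C=C/c1ccc(Cl)cc1`, compound 2 `COc1cc(/C=C/C(=O)c2sc(Nc3cccc(C)c3)nc2C)cc(OC)c1OC` and compound 3 `Cc1cccc(Nc2nc(C)c(C(=O)/C=C/c3ccccc3)s2)c1`. In a functional assay on NCI-H460 cells (Homo sapiens) for cytotoxicity, read by MTT assay (a lower number here means a stronger inhibitor, a higher number a weaker inhibitor), compound 1 gives only a limit of the assay, > 25000 nM, and not a number (the limit of > 25000 nM in this assay, at which 1 of the 3 values shown sits). In this assay compound 2 gives 19800 nM. Compound 3 gives 21800 nM in this assay, and the gap between compound 2 and compound 3 lies within the scatter of repeated measurements, so neither can be called the stronger inhibitor. The unmeasured compound 4 `COc1cc(/C=C/C(=O)c2sc(Nc3cccc(Cl)c3)nc2C)cc(OC)c1OC` differs from compound 2 in one place: chloro in place of methyl on an aromatic carbon. Among the compounds with values here, no measured pair in this set shows this change, so its effect is not known from these data; the only guide is that the number recorded for compound 2, 19800 nM, and the number recorded for compound 3, 21800 nM, both sit at weak inhibition. Compound 4 is therefore expected to give about 18000 nM in this assay, with a range from 8000 nM to 40000 nM. The expected step of a 1.1-fold lower number from compound 2 to compound 4 (0.04 log units; within the scatter) stays within the scatter.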

Compound 4, half-maximal inhibitory concentration: > 25000 nM
Compound 4 was reported as a limit; the forecaster's own chance of this, stated with the estimate: 25%; middle value at least 1.3-fold (0.14 log units) away from the limit.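

Within the data shown here, this is the first pair in the set that shows chloro in place of methyl on this ring, and in this assay the change gives an at least 1.2-fold higher number from compound 2 to compound 4 (0.10 log units; that floor lies within the scatter). Compound 4 gives > 25000 nM, which is a limit and not a number. The size of the step therefore stays unknown, its floor lies within the scatter, and the swap did not yield a stronger inhibitor at this position, with compound 4 now sharing its limit with compound 1: the limit of > 25000 nM in this assay, at which 2 of the 4 values shown sit.

Still open, as far as these compounds go, is whether chloro in place of methyl would read the same way on compound 3, which carries an unsubstituted phenyl in place of the trimethoxyphenyl of compound 2. Also open, from the compounds shown here alone, is whether a different group at this place on the ring, such as an amine or a carboxylic acid, would give a measurable number in this assay.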